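Swapping a Small Amide for an Azetidine Urea

A few compounds are considered here, and "the series" means these few. Any claim that something is new, unique, unknown or untested is made for them only; others in the source may bear on it.

Of the compounds shown here, three sharing one core have been measured in a functional assay on MIA PaCa-2 cells (Homo sapiens) for inhibition, read by MTT assay, with a stated time of 7 days; on this read-out higher numbers stand for weaker inhibition and lower numbers for stronger inhibition. Compound 1 `CCOC(=O)[C@@H]1CCCN(S(=O)(=O)c2ccc(S(=O)(=O)N(CC)CC)nc2)C1` gives 5600 nM, compound 2 `CCN(CC)S(=O)(=O)c1ccc(S(=O)(=O)N2CCC[C@@H](C(=O)N(C)C(C)C)C2)cc1` gives 6200 nM, and compound 3 `CCOC(=O)[C@H]1CCN(S(=O)(=O)c2ccc(S(=O)(=O)N(CC)CC)cc2)C1` gives 29200 nM. Among these three numbers compound 2 holds the second highest; its value and that of compound 1 fall within the usual scatter of repeated measurements, whereas compound 3 sits beyond that scatter with a higher number, meaning weaker inhibition. Compound 4 `CCN(CC)S(=O)(=O)c1ccc(S(=O)(=O)N2CCC[C@@H](C(=O)NC3CN(C(=O)NC(C)(C)C)C3)C2)cc1` differs from compound 2 in one place: (1-((tert-butyl)carbamoyl)azetidin-3-yl)amino in place of isopropyl(methyl)amino on a carbonyl carbon. Among the compounds with values here, no measured pair shows a change of this kind, so its effect is unknown. For compound 4 a step within or only slightly beyond the scatter is expected in this assay, in either direction, giving an estimated 5000 nM with a range from 1500 nM to 16000 nM. The step this estimate implies is expected to be a 1.2-fold lower number from compound 2 to compound 4 (0.09 log units; within the scatter).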

Compound 4, half-maximal inhibitory concentration: 3400 nM
The estimate for compound 4 lay 1.5-fold (0.17 log units) above the measured number; measured number inside the range.
By their numbers in this assay, from the lowest: compounds 4, 1 and 2 (each within the scatter of the next); then compound 3.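

In this assay, putting (1-((tert-butyl)carbamoyl)azetidin-3-yl)amino in place of isopropyl(methyl)amino on a carbonyl carbon gives a 1.8-fold lower number from compound 2 to compound 4 (0.26 log units; within the scatter). This position therefore accepts a far bigger group carrying a four-membered ring, and the number stays within the scatter. Nothing available explains this outcome.

Still open, on these data alone, is how a hydroxyl group in this place, which would give a carboxylic acid, or a plain unsubstituted amine would read. Also open, as far as these compounds go, is whether any group here can move the number beyond the scatter.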